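The source may report more compounds than this note shows. Statements on the series, on what has been measured and on what is new or still open speak of the compounds shown alone.

Working notes on the series in a functional assay on DLA cells (Mus musculus) for cytotoxicity, read by LDH release, with a stated time of 48 h; a lower number here means a stronger inhibitor, a higher number a weaker inhibitor. Compound 1 `Cc1cc(C(=O)c2ccccc2)ccc1OCC(=O)Nc1nc(-c2ccccc2)cs1` gives 23000 nM, compound 2 `Cc1ccc(C(=O)c2ccc(OCC(=O)Nc3nc(-c4ccccc4)cs3)c(C)c2)cc1` gives 27100 nM and compound 3 `Cc1cc(C(=O)c2ccc(F)cc2)ccc1OCC(=O)Nc1nc(-c2ccccc2)cs1` gives 34700 nM. Compound 3 cannot be separated from the other two, since a 1.5-fold higher number from compound 1 to compound 3 (0.18 log units; within the scatter) and a 1.3-fold higher number from compound 2 to compound 3 (0.11 log units; within the scatter) both lie within the scatter.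

Compound 4 `Cc1cc(C(=O)c2cccc(Br)c2)ccc1OCC(=O)Nc1nc(-c2ccccc2)cs1` differs from compound 3 in one place: 3-bromophenyl in place of 4-fluorophenyl on a carbonyl carbon. In words, this is 3-bromophenyl in place of 4-fluorophenyl on a carbonyl carbon. The relevant evidence is the three measured changes to this same aryl group: a 1.2-fold higher number from compound 1 to compound 2 (0.07 log units; within the scatter), with methyl in place of hydrogen, along with the two steps above. None goes beyond the scatter. Among the measured compounds shown here, no measured compound carries bromine, so the data do not test that group directly. On this limited evidence, no step beyond the scatter is expected in this assay, and no direction is favoured with any confidence.

The estimated step is a 1.2-fold lower number from compound 3 to compound 4 (0.09 log units; within the scatter). For compound 4 the expected value is 28000 nM, with an estimated range from 15000 nM to 52000 nM.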

Compound 4, half-maximal inhibitory concentration: 23600 nM
For compound 4 the middle estimate is 1.2-fold (0.07 log units) above the measured one; the measured number falls inside the stated range.
By their numbers in this assay, from the lowest: compounds 1, 4, 2 and 3 (each within the scatter of the next).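

Bromine enters the series as 3-bromophenyl on a carbonyl carbon, and in this assay each comparison with the earlier compounds stays within the scatter (three steps: a 1.5-fold lower number from compound 3 to compound 4 (0.17 log units; within the scatter); a 1.1-fold lower number from compound 2 to compound 4 (0.06 log units; within the scatter); a 1.0-fold higher number from compound 1 to compound 4 (0.01 log units; within the scatter)). The aryl group at this place has now carried 4-fluorophenyl, 4-methylphenyl and 3-bromophenyl as well as the unsubstituted ring of compound 1, and these four compounds give no order among the groups and no step beyond the scatter. Nothing at hand explains why this change leaves the number within the scatter.

Still open, as far as these compounds go, is whether an amine or a carboxylic acid on this aryl group would give a step beyond the scatter. A longer chain in place of the aryl group on the carbonyl carbon poses the same question.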